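The source may hold more compounds than are shown below. What is called first, only, known or untested is meant among the compounds shown, and "the series" means these compounds.

The shared core of compound 1 `CCCCCCCCCCCCCCc1ccc(NC(=O)Nc2c(C(C)C)cccc2C(C)C)cc1` is kept throughout this set, and the compounds differ only in the chain on one aromatic carbon. In an assay on isolated protein for inhibition of acyl-CoA:cholesterol acyltransferase (Oryctolagus cuniculus) (a higher number here means a weaker inhibitor, a lower number a stronger inhibitor), compound 1 gives 500 nM, the second highest of the three numbers shown. Compound 2 `CC(C)c1cccc(C(C)C)c1NC(=O)Nc1ccccc1`, with hydrogen at that position, gives 910 nM, which lies within the scatter of compound 1. Compound 3 `CCCCc1ccc(NC(=O)Nc2c(C(C)C)cccc2C(C)C)cc1`, with butyl there, gives 29 nM. The two measured steps that bear on the question are a 17-fold lower number from compound 1 to compound 3 (1.24 log units; beyond the scatter) and a 31-fold lower number from compound 2 to compound 3 (1.50 log units; beyond the scatter). Compound 4 `CCCCCCCCCCCc1ccc(NC(=O)Nc2c(C(C)C)cccc2C(C)C)cc1` has not yet been measured; it differs from compound 1 in that (hydrogen in place of propyl on a saturated chain carbon, ten or more bonds along the chain from an aromatic carbon). This change goes only part of the way from compound 1 toward compound 3, so a step in the same direction as a 17-fold lower number from compound 1 to compound 3 (1.24 log units; beyond the scatter) but of smaller size is expected. Compound 4 is therefore estimated to give about 200 nM in this assay, with a range from 60 nM to 600 nM. That estimate corresponds to an expected 2.5-fold lower number from compound 1 to compound 4 (0.40 log units; beyond the scatter).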

Compound 4, half-maximal inhibitory concentration: 9 nM
Compound 4: middle estimate off by 22-fold (1.35 log units), on the high side; the whole stated range lies above it.
By their numbers in this assay, from the lowest: compound 4; then compound 3; then compounds 1 and 2 (each within the scatter of the next).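

In this assay, the gain does not stop at butyl: undecyl in place of hydrogen gives a 100-fold lower number from compound 2 to compound 4 (2.00 log units; beyond the scatter), and heptyl added to the end of the butyl chain still gives a 3.2-fold lower number from compound 3 to compound 4 (0.51 log units; beyond the scatter). The trend then reverses within a short stretch of chain, since taking propyl off the end of the chain of compound 1 gives a 56-fold lower number from compound 1 to compound 4 (1.74 log units; beyond the scatter), which leaves compound 1 within the scatter of compound 2, the compound with only hydrogen at this position. Across these compounds the number falls from hydrogen through butyl to undecyl, and compound 1 alone goes against that fall.

Nothing given here accounts for this turn. Still open, as far as these compounds go, are the chain length at which the number starts to climb, and whether an undecyl chain ending in a carboxylic acid or an amine would keep the number as low.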